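The compounds below may be only part of what the source reports. "The series", "measured", "known", "first", "only" and "open" are said of these compounds alone.

Compound 1 `COc1cc(N)c(Cl)cc1NC(=O)C1CCN(Cc2cccc(C#N)c2)CC1`: in a functional assay on the whole organism for antagonist activity, with Mus musculus as the target (a higher number here means that more compound is needed for the effect, a lower number that less compound is needed), compound 1 reaches only the limit of the assay, > 4 mg/kg.
Compound 2 `COc1cc(N)c(Cl)cc1NC(=O)C1CCN(Cc2ccsc2)CC1`: in this assay compound 2 gives 3.4 mg/kg.
Compound 3 `COc1cc(N)c(Cl)cc1NC(=O)C1CCN(Cc2cccc(Cl)c2)CC1`: in this assay compound 3 likewise reaches only the limit, > 4 mg/kg.

Compound 1 therefore stands at a limit rather than at a number, and the same is true of compound 3, which is what the limit of > 4 mg/kg in this assay, at which 2 of the 3 values shown sit, records; only compound 2 yields a measured dose. Among the measured compounds shown here, the step of an at least 1.1-fold lower number from compound 1 to compound 2 (0.07 log units; that floor lies within the scatter), where thiophen-3-yl replaces 3-cyanophenyl on the saturated chain carbon bound to the ring amine nitrogen, is the one exchange at that position that brings a number, and it remains within the scatter. The step of an at least 1.1-fold higher number from compound 2 to compound 3 (0.07 log units; that floor lies within the scatter) goes back up to the limit when 3-chlorophenyl takes that place, again within the scatter at its floor.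

Compound 4 `CCOc1ccc(CN2CCC(C(=O)Nc3cc(Cl)c(N)cc3OC)CC2)cc1` differs from compound 1 by 4-ethoxyphenyl in place of 3-cyanophenyl on a saturated chain carbon bound to an amine nitrogen in a ring. For the measured compounds named here, no measured step introduces a 4-ethoxyphenyl group, so the two steps around compound 2 are the only guide, and neither reaches beyond the scatter. The expected step is therefore a number no higher from compound 1 to compound 4 (the limit leaves the size open), that is, no change beyond the scatter, with a fair chance that compound 4 again reports only a limit. The estimate for compound 4 in this assay is 4 mg/kg, with a range from 2 mg/kg to 8 mg/kg.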

Compound 4, dose for half-maximal effect: 6.3 mg/kg
Beside the measured number, compound 4's estimate is 1.6-fold (0.20 log units) below it; the range from low to high includes it.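

Compound 4 adds a second measured dose at this position, so two groups there can now be compared by number rather than against a limit: the step is a 1.9-fold higher number from compound 2 to compound 4 (0.27 log units; within the scatter). In this assay, among the compounds shown here, thiophen-3-yl and 4-ethoxyphenyl therefore cannot be told apart, although one is a sulfur-containing ring and the other a six-membered aromatic ring of carbon carrying an ethoxy group, and 4-ethoxyphenyl is also the first phenyl group in this small set to give a measured dose rather than a limit. The steps to compound 4 from compound 1 and from compound 3 cannot be read, so it stays unknown how 4-ethoxyphenyl compares with 3-cyanophenyl or 3-chlorophenyl, since both of those compounds give only a limit: the limit of > 4 mg/kg in this assay, at which 2 of the 4 values shown sit.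

The compounds shown leave open whether any group at this place can move the dose beyond the scatter, since the one step that can be read in full stays within it. They also say nothing about a phenyl ring carrying an amine or a carboxylic acid, or about a plain alkyl chain such as butyl in place of the aromatic ring.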